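This account rests on a few compounds, and the source may have more. Where it says the series, first, only, none or still open, it means among the compounds named here.

Measured in an assay on cells (strain Sprague-Dawley) for inhibition of Polyunsaturated fatty acid 5-lipoxygenase (Rattus norvegicus), with a stated time of 30 min; a lower number here means a stronger inhibitor, a higher number a weaker inhibitor:

Compound 1, `CS(=O)(=O)c1ccc(-c2nc(SCCCOC(=O)/C=C/c3ccc(O)c(O)c3)nn2-c2ccc(Br)cc2)cc1`, gives 790 nM.
Compound 2, `CS(=O)(=O)c1ccc(-c2nc(SCCCOC(=O)/C=C/c3ccc(O)c(O)c3)nn2-c2ccc(F)cc2)cc1`, gives 710 nM.
Compound 3, `CC(=O)Oc1ccc(/C=C/C(=O)NCCCSc2nc(-c3ccc(S(C)(=O)=O)cc3)n(-c3ccc(Br)cc3)n2)cc1OC(C)=O`, gives 990 nM.

Compound 1 and compound 2 share a core and differ in one place only: fluoro in place of bromo on an aromatic carbon. In this assay this change produced a 1.1-fold lower number from compound 1 to compound 2 (0.05 log units; within the scatter), so the two values lie within the scatter of each other and no ordering between them can be read.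

Compound 3 differs from compound 1 in more than one place, and the difference between the two cores is not broken down here. Its value in this assay is within the scatter of both compound 1 and compound 2, so the three measured compounds cannot be ranked against one another.

Compound 4, `CC(=O)Oc1ccc(/C=C/C(=O)NCCCSc2nc(-c3ccc(S(C)(=O)=O)cc3)n(-c3ccc(F)cc3)n2)cc1OC(C)=O`, has not yet been measured. It relates to compound 3 as compound 2 relates to compound 1: fluoro in place of bromo on an aromatic carbon. The place of the change is described in the same words for both pairs, so this is the same change made on a different core. For the measured compounds named here, the only precedent is the step from compound 1 to compound 2, which was a 1.1-fold lower number from compound 1 to compound 2 (0.05 log units; within the scatter), and on that basis compound 4 is expected to sit close to compound 3 in this assay, with an estimated step of a 1.1-fold lower number from compound 3 to compound 4 (0.04 log units; within the scatter) because a 1.1-fold lower number from compound 1 to compound 2 (0.05 log units; within the scatter). Compound 4 is thus estimated at 900 nM, between 450 nM and 1800 nM.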

Compound 4, half-maximal inhibitory concentration: 980 nM
Compound 4: the middle estimate sits 1.1-fold (0.04 log units) below what was measured; low and high end bracket the measured number.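

In this assay, fluoro in place of bromo on the second core gave a 1.0-fold lower number from compound 3 to compound 4 (0.00 log units; within the scatter), so these two values cannot be ordered. Set beside the earlier step on the other core, the new step shows no difference in how the change behaves on the two cores: the same change on two cores in this assay, a 1.1-fold lower number (0.05 log units; within the scatter) from compound 1 to compound 2 and a 1.0-fold lower number (0.00 log units; within the scatter) from compound 3 to compound 4, 1.1-fold (0.04 log units) apart, within the scatter of two such steps This shows only that the exchange of 4-bromophenyl for 4-fluorophenyl left the number within the scatter on both cores; since neither step has a measurable size, it does not show that an effect of this change carries from one core to the other, and two cores are too few to support a rule for the wider series.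

The compounds shown leave open whether a chloro group, a methoxy group or a plain hydrogen at the same place would also stay within the scatter of these values. They also leave open how a longer chain, or an amide link paired with free hydroxyl groups, would read in this assay, as the ester with free hydroxyl groups in compound 1 and compound 2 and the amide with acetate groups in compound 3 and compound 4 differ in more than one place.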